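This account rests on a few compounds, and the source may have more. Where it says the series, first, only, none or still open, it means among the compounds named here.

Working notes on the series. Compound 1 `CCc1ccccc1-n1nncc1CN1C(=O)C2(C(C#N)=C(N)Oc3c(N)cc4nc5ccccc5nc4c32)c2ccccc21` in a functional assay on MCF7 cells (Homo sapiens) for antiproliferative activity, read by MTT assay, with a stated time of 48 h (a lower number here means a stronger inhibitor, a higher number a weaker inhibitor), gives 24600 nM. Compound 2 `N#CC1=C(N)Oc2c(N)cc3nc4ccccc4nc3c2C12C(=O)N(Cc1cnnn1-c1ccc([N+](=O)[O-])cc1)c1ccccc12` in this assay returns > 50000 nM, which is a limit of the assay and not a number. Going by the values given here, the single measured step, an at least 2.0-fold higher number from compound 1 to compound 2 (0.30 log units; that floor lies within the scatter), replaces 2-ethylphenyl on the aromatic nitrogen with 4-nitrophenyl and runs toward weaker inhibition; only its floor is known, because compound 2 sits at the limit of > 50000 nM in this assay, at which 1 of the 2 values shown sits.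

Compound 3 `Cc1ccc(-n2nncc2CN2C(=O)C3(C(C#N)=C(N)Oc4c(N)cc5nc6ccccc6nc5c43)c3ccccc32)cc1C` differs from compound 2 at the same aromatic nitrogen: 3,4-dimethylphenyl in place of 4-nitrophenyl on an aromatic nitrogen. The aryl group thereby returns to a carbon-only substitution pattern, as in compound 1, which carries 2-ethylphenyl. Among the compounds with values here, the only step bearing on this change is the one from compound 1 to compound 2, and compound 3 reverses its direction.

The step of an at least 1.6-fold lower number from compound 2 to compound 3 (0.22 log units; that floor lies within the scatter) is therefore expected to run toward stronger inhibition, its true size open since compound 2 gives only a limit. Compound 3 is estimated at 30000 nM in this assay, with a range of 12000 nM to 70000 nM, in line with what compound 1 shows at 24600 nM.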

Compound 3, half-maximal inhibitory concentration: > 50000 nM
Compound 3 was reported as a limit; the forecaster's own chance of this, stated with the estimate: 30%; middle value at least 1.6-fold (0.22 log units) from the limit.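

In this assay compound 3 gives > 50000 nM, a limit of the assay and not a number. Returning to a carbon-only aryl group on the aromatic nitrogen therefore does not restore a readable value, and 3,4-dimethylphenyl in place of 2-ethylphenyl gives an at least 2.0-fold higher number from compound 1 to compound 3 (0.30 log units; that floor lies within the scatter), a step of which only the floor is known; among the three compounds, only the 2-ethylphenyl of compound 1 gives a readable number, so the loss of a readable value is not tied to 4-nitrophenyl alone. The change from 4-nitrophenyl to 3,4-dimethylphenyl cannot be read, because compound 2 and compound 3 share one limit: the limit of > 50000 nM in this assay, at which 2 of the 3 values shown sit.

From the compounds shown here alone, how far compound 2 and compound 3 lie beyond that limit remains open, as does whether the readable value of compound 1 depends on the ethyl group itself or on its place on the phenyl ring. Also open, going by these compounds, is whether an amine or a carboxylic acid on this phenyl ring, or a longer chain such as propyl in place of the ethyl group, gives a readable value.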